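Triazole for Aminothiadiazole on a Sugar Thioether Arm

The source may report more compounds than this note shows. Statements on the series, on what has been measured and on what is new or still open speak of the compounds shown alone.

The series is assessed in a functional assay on SW1573 cells (Homo sapiens) for antiproliferative activity, read by sulforhodamine B assay, with a stated time of 48 h; on this read-out higher numbers stand for weaker inhibition of growth and lower numbers for stronger inhibition of growth. Compound 1 `Nc1nnc(SC[C@H]2O[C@@H](OCc3noc(-c4ccc(Cl)cc4)n3)[C@@H]3OC4(CCCC4)O[C@@H]32)s1` gives 17000 nM, and this is the lower of the two numbers that have been obtained in this assay. Compound 2 `CC1(C)O[C@H]2[C@H](OCc3noc(-c4ccc([N+](=O)[O-])cc4)n3)O[C@H](CO)[C@H]2O1` gives 60000 nM in this assay, a higher number than compound 1, and the gap between the two lies beyond the usual scatter. Compound 3 `Cc1ccc(S(=O)(=O)OC[C@H]2O[C@@H](OCc3noc(-c4ccc([N+](=O)[O-])cc4)n3)[C@@H]3OC4(CCCC4)O[C@@H]32)cc1` does not yield a number in this assay, only the limit > 100000 nM, as noted in the limit of > 100000 nM in this assay, at which 1 of the 3 values shown sits.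

The step of interest leads from compound 1 to compound 4 `Clc1ccc(-c2nc(CO[C@@H]3O[C@H](CSc4ncn[nH]4)[C@H]4OC5(CCCC5)O[C@@H]34)no2)cc1`, which has not yet been measured in this assay. The structural change is 1H-1,2,4-triazol-5-yl in place of 5-amino-1,3,4-thiadiazol-2-yl on a sulfur. For the measured compounds named here, both groups are five-membered aromatic rings with three hetero atoms joined through the sulfur, so the change is a modest one, and no step between measured compounds is available to gauge it. The account therefore expects only a small shift in this assay, within or close to the scatter, and if anything toward a somewhat higher number. Compound 4 is estimated at 25000 nM in this assay, with a range from 8000 nM to 80000 nM. This estimate means a step of a 1.5-fold higher number from compound 1 to compound 4 (0.17 log units; within the scatter).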

Compound 4, concentration for 50% growth inhibition: 10000 nM
The estimate for compound 4 lay 2.5-fold (0.40 log units) above the measured number, within the range that was stated.
By their numbers in this assay, from the lowest: compounds 4 and 1 (each within the scatter of the next); then compound 2. At a limit, above all of these: compound 3.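

For the compounds shown here, the one step that can be read at this position in this assay is a 1.7-fold lower number from compound 1 to compound 4 (0.23 log units; within the scatter), so on a sulfur whose other neighbour is a saturated chain carbon, this read-out does not separate 1H-1,2,4-triazol-5-yl from 5-amino-1,3,4-thiadiazol-2-yl. The earlier compounds shown here could not show this, since compound 2 and compound 3 each differ from compound 1 in more than one place, whereas this pair shows that the amino group and the ring sulfur of the leaving group can both be absent without a change beyond the scatter. Nothing measured here accounts for why the two groups read alike.

The compounds shown leave open whether any group on this sulfur arm can move the number beyond the scatter, for example a carboxylic acid in place of the ring or an amine or a longer chain carried on the triazole. They also leave open whether the same exchange reads alike when a nitro group stands in place of the chlorine of compound 4.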